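Branching the Alkyl Chain on the Shared Core

This account rests on a few compounds, and the source may have more. Where it says the series, first, only, none or still open, it means among the compounds named here.

Compound 1 `CCn1cnc2ncnc(N)c21`: in an assay on CHO cells for displacement of a labelled ligand from adenosine receptor A1 (Homo sapiens) (on this read-out lower numbers stand for stronger inhibition and higher numbers for weaker inhibition), compound 1 gives > 100000 nM, a limit of the assay.
Compound 2 `CCCn1cnc2ncnc(N)c21`: in this assay compound 2 gives > 100000 nM, a limit of the assay.
Compound 3 `CC(C)n1cnc2ncnc(N)c21`: in this assay compound 3 gives 20000 nM.

For the measured compounds named here, compound 3 stands apart as the only compound with a number; the other two sit at the limit of > 100000 nM in this assay, at which 2 of the 3 values shown sit. The steps of an at least 5.0-fold lower number from compound 1 to compound 3 (0.69 log units; beyond the scatter) and an at least 5.0-fold lower number from compound 2 to compound 3 (0.69 log units; beyond the scatter) both run toward compound 3, so the branched chain on the aromatic nitrogen goes with the lower number.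

Compound 4 `CCC(C)n1cnc2ncnc(N)c21` differs from compound 3 by methyl in place of hydrogen on a saturated chain carbon, two bonds along the chain from an aromatic nitrogen. The same change between compound 1 and compound 2 reads a step that the two limits leave unreadable from compound 1 to compound 2, so that pair gives no guide. What does bear on compound 4 is that it keeps the branching at the carbon bound to the aromatic nitrogen that compound 3 has, and adds one methyl further out. The expected step in this assay from compound 3 to compound 4 is therefore small, if anything a modest lowering, estimated as a 2.0-fold lower number from compound 3 to compound 4 (0.30 log units; within the scatter). For compound 4 the estimate in this assay is 10000 nM, expected to lie between 3000 nM and 40000 nM.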

Compound 4, inhibition constant: > 100000 nM
Compound 4: a limit, no number; the forecaster's own chance of this, stated with the estimate: 15%; at least 10-fold (1.00 log units) between middle value and limit.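

The branching at the saturated chain carbon bound to the aromatic nitrogen does not hold the lower number by itself: going from isopropyl to sec-butyl, with methyl in place of hydrogen on a saturated chain carbon, two bonds along the chain from an aromatic nitrogen, gives an at least 5.0-fold higher number from compound 3 to compound 4 (0.69 log units; beyond the scatter). For the compounds shown here, this is the first size that can be read for this change in this assay, since the same change from ethyl to propyl lies between two limits, and the other new steps, which also join limits, cannot be read either. The link between a branched chain and a lower number therefore rests on compound 3 alone, compound 4 goes against it, and compound 3 remains the only compound with a number: the limit of > 100000 nM in this assay, at which 3 of the 4 values shown sit.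

The three limits leave the order among compound 1, compound 2 and compound 4 open. Going by these compounds, it also remains open how a cyclopropyl, a tert-butyl or a benzyl group on the aromatic nitrogen would read in this assay, and whether any group there would give a number lower than that of compound 3, which stands at 20000 nM.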